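The source may report more compounds than this note shows. Statements on the series, on what has been measured and on what is new or still open speak of the compounds shown alone.

Compound 1, `N#Cc1ccc(C2OCC(C/C=C\CCC(=O)O)C(c3cccnc3)O2)cc1`: in an assay for inhibition of Thromboxane-A synthase (Homo sapiens), using microsomes (on this read-out higher numbers stand for weaker inhibition and lower numbers for stronger inhibition), compound 1 gives 24 nM.
Compound 2, `O=C(O)CC/C=C\CC1COC(c2cccc3ccccc23)OC1c1cccnc1`: in this assay compound 2 gives 40 nM.
Compound 3, `CC(C)(Oc1ccccc1)C1OCC(C/C=C\CCC(=O)O)C(c2cccnc2)O1`: in this assay compound 3 gives 52 nM.

Compound 3 has the highest number of the three. Its step from compound 2, a 1.3-fold higher number from compound 2 to compound 3 (0.11 log units; within the scatter), is within the scatter, while its step from compound 1, a 2.2-fold higher number from compound 1 to compound 3 (0.34 log units; beyond the scatter), is modest but beyond it. All three compounds share the same core and differ only in the group carried on a saturated ring carbon.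

Compound 4, `CC(C)(Oc1ccccc1Br)C1OCC(C/C=C\CCC(=O)O)C(c2cccnc2)O1`, differs from compound 3 in one place: bromo in place of hydrogen on an aromatic carbon. The phenoxy group thus becomes a 2-bromophenoxy group.

Among the compounds with values here, none of the measured steps matches this change. Each of them, a 1.7-fold higher number from compound 1 to compound 2 (0.22 log units; within the scatter), a 2.2-fold higher number from compound 1 to compound 3 (0.34 log units; beyond the scatter) and a 1.3-fold higher number from compound 2 to compound 3 (0.11 log units; within the scatter), exchanges the whole group on the saturated ring carbon rather than adding one atom to an aromatic carbon of it, and all three steps were small. Adding a bromine at this position has no direct precedent here, so no step beyond the scatter is expected in this assay, in either direction.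

Compound 4 is therefore expected to give about 50 nM in this assay, within a range of 20 nM to 130 nM. This estimate means a step of a 1.0-fold lower number from compound 3 to compound 4 (0.02 log units; within the scatter), which is expected to stay within the scatter.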

Compound 4, half-maximal inhibitory concentration: 29 nM
Compound 4: the middle estimate sits 1.7-fold (0.24 log units) above what was measured; the range from low to high includes it.
By their numbers in this assay, from the lowest: compounds 1, 4, 2 and 3 (each within the scatter of the next, the first and the last beyond it).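

Placing a bromo on an aromatic carbon of the phenoxy group, ortho to a large group, gives a 1.8-fold lower number from compound 3 to compound 4 (0.25 log units; within the scatter) in this assay, so this step stays within the usual scatter of repeated measurements. The earlier steps shown here exchanged the whole group on the saturated ring carbon, whereas this pair changes a single hydrogen on the aromatic ring of that group, and it shows that a bromine atom at this position is compatible with a reading in the same range as that of compound 3. No supporting measurement is available to explain this result, and this single pair cannot show whether the bromo has any real effect at all.

On these data alone, it remains open whether a smaller halogen such as chloro, or a different group such as methoxy or an amine, would give a step beyond the scatter at this same aromatic carbon. As far as these compounds go, it is also open whether a bromo on another carbon of this ring, or on the aromatic ring of compound 1 or compound 2, would behave in the same way.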